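A triazole takes the isoxazole's place

The compounds below may be only part of what the source reports. "The series", "measured", "known", "first", "only" and "open" are said of these compounds alone.

Three compounds on a shared core have been run in a functional assay on the whole organism for inhibition, with Rattus norvegicus as the target, read by paw edema; a lower number here means that less compound is needed, a higher number that more compound is needed for the effect. Compound 1 `O=C(O)c1cc(-c2cccs2)ccc1O` gives 60 mg/kg. Compound 3 `O=C(O)c1cc(-c2ccno2)ccc1O` gives 110 mg/kg, the higher of the two numbers, yet the step of a 1.8-fold higher number from compound 1 to compound 3 (0.26 log units; within the scatter) is within the scatter. For compound 2 `O=C(O)c1cc(-c2cc[nH]n2)ccc1O` the assay reports only a limit, > 250 mg/kg. The steps of an at least 4.1-fold higher number from compound 1 to compound 2 (0.61 log units; beyond the scatter) and an at least 2.2-fold lower number from compound 2 to compound 3 (0.35 log units; beyond the scatter) both run past (the limit of > 250 mg/kg in this assay, at which 1 of the 3 values shown sits).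

Compound 4 `O=C(O)c1cc(-n2cnnc2)ccc1O` differs from compound 3 by 4H-1,2,4-triazol-4-yl in place of 1,2-oxazol-5-yl on an aromatic carbon. Going by the values given here, two measured steps bear on such a ring exchange: a 1.8-fold higher number from compound 1 to compound 3 (0.26 log units; within the scatter) was within the scatter, while an at least 2.2-fold lower number from compound 2 to compound 3 (0.35 log units; beyond the scatter) was at least modest. The ring that enters in compound 4 lies closer in its make-up to the 1H-pyrazol-3-yl of compound 2 than to the thiophen-2-yl of compound 1, and since the step of an at least 2.2-fold lower number from compound 2 to compound 3 (0.35 log units; beyond the scatter) ran at least modestly toward the lower number, a modest rise, a 1.6-fold higher number from compound 3 to compound 4 (0.21 log units; within the scatter), is expected in this assay. The estimate for compound 4 is 180 mg/kg, from 90 mg/kg to 400 mg/kg, with a real chance that only a limit is returned.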

Compound 4, dose for half-maximal effect: > 250 mg/kg
Compound 4 ended at the assay's limit; the forecaster's own chance of this, stated with the estimate: 30%; middle value at least 1.3-fold (0.14 log units) from the limit.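

In this assay, the exchange of rings at this place, meta to a carboxy group and para to a hydroxy group, proved larger than the earlier ring steps suggested: an at least 2.2-fold higher number from compound 3 to compound 4 (0.35 log units; beyond the scatter), and an at least 4.1-fold higher number from compound 1 to compound 4 (0.61 log units; beyond the scatter). Compound 4 gives only a limit, > 250 mg/kg. Neither the 1,2-oxazol-5-yl nor the 4H-1,2,4-triazol-4-yl ring has a hydrogen-bond donor and both have the same count of heavy atoms, so a step beyond the scatter does not depend on a change in either count, and the two rings with only nitrogen as hetero atoms now end alike: the limit of > 250 mg/kg in this assay, at which 2 of the 4 values shown sit.

The step between compound 2 and compound 4 cannot be read, as both are limits. As far as these compounds go, whether a methyl group or an amine on the 4H-1,2,4-triazol-4-yl ring would bring the number back down stays open.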